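From Methylsulfanyl to Allylsulfanyl: One Small Change

The source may hold more compounds than are shown below. What is called first, only, known or untested is meant among the compounds shown, and "the series" means these compounds.

compound 1 `CCC[S+]([O-])C/C=C\SSC` gives 26000 nM
compound 2 `CCC[S+]([O-])C/C=C/SSC` gives 28000 nM
compound 3 `COc1ccc(CS/C=C\C[S+]([O-])Cc2ccc(OC)cc2)cc1` gives > 200000 nM (a limit, not a number)

All three results come from a functional assay on WHCO1 cells (Homo sapiens) for antiproliferative activity, read by MTT assay, with a stated time of 48 h; a higher number here means a weaker inhibitor, a lower number a stronger inhibitor. Among the compounds with values here, compound 1 stands level with compound 2, and the only measured step (a 1.1-fold higher number from compound 1 to compound 2 (0.03 log units; within the scatter)) switches a double bond from Z to E. Compound 3 gives only a limit. Compound 4 `C=CCSS/C=C\C[S+]([O-])CCC` keeps the core of compound 1 but turns methylsulfanyl into allylsulfanyl (vinyl in place of hydrogen on a saturated chain carbon bound to a sulfur). The measured step leaves that group untouched, so it gives no size for this change. Starting from compound 1 (26000 nM), no shift beyond the scatter is expected in this assay. The expected step is small (a 1.3-fold lower number from compound 1 to compound 4 (0.11 log units; within the scatter)). Compound 4 is estimated at 20000 nM, with an expected range from 9000 nM to 42000 nM.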

Compound 4, half-maximal inhibitory concentration: 23000 nM
Compound 4: middle estimate off by 1.2-fold (0.06 log units), on the low side; the measured number falls inside the stated range.
By their numbers in this assay, from the lowest: compounds 4, 1 and 2 (each within the scatter of the next). At a limit, above all of these: compound 3.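

Turning methylsulfanyl into allylsulfanyl gives a 1.1-fold lower number from compound 1 to compound 4 (0.05 log units; within the scatter) in this assay. The earlier step changed only the double bond, whereas this one shows that, on the core of compound 1, vinyl in place of hydrogen on a saturated chain carbon bound to a sulfur leaves the reading level. Nothing shown here offers an explanation for this result.

As far as these compounds go, whether a longer chain or an amine in place of the allyl would also stay level with compound 1 remains open. So does whether allylsulfanyl would read the same on the E double bond of compound 2.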